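Hydroxy for methyl on the triazole aryl of a sesquiterpene ester

A few compounds are considered here, and "the series" means these few. Any claim that something is new, unique, unknown or untested is made for them only; others in the source may bear on it.

Measured compounds in a functional assay on SiHa cells (Homo sapiens) for antiproliferative activity, read by MTT assay, with a stated time of 48 h; a lower number here means a stronger inhibitor, a higher number a weaker inhibitor:
- compound 1 `C/C(=C\CC/C(C)=C/CC[C@@H]1[C@@]2(C)CCC(=O)C(C)(C)[C@H]2CC[C@@]1(C)O)CC/C=C(\C)C(=O)OCc1cn(-c2cccc(C)c2)nn1`: reported only as a limit, > 150000 nM
- compound 2 `C/C(=C\CC/C(C)=C/CC[C@@H]1[C@@]2(C)CCC(=O)C(C)(C)[C@H]2CC[C@@]1(C)O)CC/C=C(\C)C(=O)OCc1cn(-c2ccccc2)nn1`: 149000 nM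
- compound 3 `C/C(=C\CC/C(C)=C/CC[C@@H]1[C@@]2(C)CCC(=O)C(C)(C)[C@H]2CC[C@@]1(C)O)CC/C=C(\C)C(=O)OCc1cn([C@@H]2C[C@@H](n3cc(C)c(=O)[nH]c3=O)O[C@H]2CO)nn1`: 41700 nM

Compound 1 stands at the limit of this assay, where (the limit of > 150000 nM in this assay, at which 1 of the 3 values shown sits); no number is known for it. For the measured compounds named here, the single step that touches compound 1, hydrogen in place of methyl on an aromatic carbon, reads a number no higher from compound 1 to compound 2 (the limit leaves the size open), so its size cannot be read. Going by the values given here, compound 3 carries a different substituent on the triazole and shows a lower value than compound 2, but no step is defined between them here.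

Compound 4 `C/C(=C\CC/C(C)=C/CC[C@@H]1[C@@]2(C)CCC(=O)C(C)(C)[C@H]2CC[C@@]1(C)O)CC/C=C(\C)C(=O)OCc1cn(-c2cccc(O)c2)nn1` differs from compound 1 by hydroxy in place of methyl on an aromatic carbon. Among the compounds with values here, no measured step shows a hydroxy entering this ring, so nothing bears directly on it. With compound 1 at a limit and compound 2 close to it, compound 4 is expected to remain weak in this assay, with a step of an at least 1.5-fold lower number from compound 1 to compound 4 (0.17 log units; that floor lies within the scatter). The estimate for compound 4 is 100000 nM, between 30000 nM and 300000 nM.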

Compound 4, half-maximal inhibitory concentration: 48000 nM
For compound 4 the middle estimate is 2.1-fold (0.32 log units) above the measured one; the measured number falls inside the stated range.
By their numbers in this assay, from the lowest: compounds 3 and 4 (each within the scatter of the next); then compound 2. At a limit, above all of these: compound 1.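

In this assay, this position on the aryl ring, meta to a large group, now gives a step that can be sized: replacing hydrogen with hydroxy reads a 3.1-fold lower number from compound 2 to compound 4 (0.49 log units; beyond the scatter). Replacing methyl with hydroxy at the same position reads an at least 3.1-fold lower number from compound 1 to compound 4 (0.49 log units; beyond the scatter), so a change here can lower the number beyond the scatter. Compound 1 is held at a limit, and this second step therefore has only a floor: the limit of > 150000 nM in this assay, at which 1 of the 4 values shown sits.

The compounds shown do not tell whether this step is particular to hydroxy, and an amine or a methoxy at the same position would test that. They also leave open whether hydroxy on another carbon of the ring would give a step of similar size.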